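Swapping a methylphenyl for a dichlorophenyl on a shared core

The source may report more compounds than this note shows. Statements on the series, on what has been measured and on what is new or still open speak of the compounds shown alone.

Within the data shown here, compound 1 `COc1cc(-n2ncnc2-c2ccc(C)cc2)cc(OC)c1OC` is the only member of this small set with a measured number. In a functional assay on MCF7 cells (Homo sapiens) for antiproliferative activity, read by MTT assay, with a stated time of 72 h (on this read-out higher numbers stand for weaker inhibition and lower numbers for stronger inhibition), compound 1 gives 540 nM. Compound 2 `COc1cc(-c2ncnn2-c2ccc(Cl)cc2Cl)cc(OC)c1OC` reaches only a limit of the assay, > 10000 nM. Compound 3 `COc1cc(-c2ncnn2-c2ccc(N)cc2)cc(OC)c1OC` likewise gives only a limit, > 10000 nM. Among the measured compounds shown here, the single one-place change among the measured compounds, a step that the two limits leave unreadable from compound 2 to compound 3, cannot be sized because of the limit of > 10000 nM in this assay, at which 2 of the 3 values shown sit. So compound 1 stands alone with a readable value, while the other two sit at the same limit.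

Compound 4 `COc1cc(-n2ncnc2-c2ccc(Cl)c(Cl)c2)cc(OC)c1OC` is the next compound to be tested. It differs from compound 1 in one place: 3,4-dichlorophenyl in place of 4-methylphenyl on an aromatic carbon. For the measured compounds named here, no measured step bears directly on this change; the only step between measured compounds is unreadable and concerns different groups. Going by the values given here, what can be said is that compound 1 is the one compound with a number, whereas compounds 2 and 3, which differ from compound 1 in more than one place, sit at the limit. The expectation for compound 4 is therefore anchored on compound 1 with wide uncertainty. Compound 4 is expected to give about 1500 nM, with a range from 300 nM to 10000 nM. That amounts to an expected step of a 2.8-fold higher number from compound 1 to compound 4 (0.44 log units; beyond the scatter), modestly toward weaker inhibition, with a real chance of only a limit.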

Compound 4, half-maximal inhibitory concentration: > 10000 nM
Compound 4 gave a limit, no number (the forecaster's own chance of this, stated with the estimate: 30%); middle value at least 6.6-fold (0.82 log units) from the limit.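

In this assay, putting 3,4-dichlorophenyl in place of 4-methylphenyl on an aromatic carbon of the five-membered aromatic ring with 3 nitrogen gives an at least 18-fold higher number from compound 1 to compound 4 (1.26 log units; beyond the scatter). Among these compounds, this is the first step in the set that can be read, and it shows that this position does not accept every substituted phenyl group equally, even though the two groups differ by only a few atoms. Compound 4 gives > 10000 nM, which is a limit of the assay and not a number, so the step marks only the smallest possible change, and its full size stays unknown: the limit of > 10000 nM in this assay, at which 3 of the 4 values shown sit.

With a single readable pair, the compounds shown leave open whether the loss follows from having chlorine on the phenyl ring, from having two substituents rather than one, or from the 3-position being occupied. A plain phenyl group, a 4-chlorophenyl group or a 4-methoxyphenyl group at this same position would begin to separate these possibilities and would show how much change this position tolerates.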